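A few compounds are considered here, and "the series" means these few. Any claim that something is new, unique, unknown or untested is made for them only; others in the source may bear on it.

Going by the values given here, compound 2 `Fc1c(F)c(F)c(CO/N=C/c2c(-c3ccc4ccccc4c3)nc3occn23)c(F)c1F` gives 1700 nM in an assay on HepG2 cells for agonist activity at nuclear receptor subfamily 1 group I member 3 (Homo sapiens), read by a luciferase reporter, with a stated time of 23 h (on this read-out higher numbers stand for an effect only at larger amounts of compound and lower numbers for an effect already at smaller amounts), the higher of the two numbers so far, though only within the scatter of compound 1. Compound 1 `Clc1ccc(CO/N=C/c2c(-c3ccc4ccccc4c3)nc3occn23)c(Cl)c1` gives 1500 nM. The step at this position is a 1.1-fold higher number from compound 1 to compound 2 (0.05 log units; within the scatter). Compound 3 `Clc1ccc(CO/N=C/c2c(-c3ccc4ccccc4c3)nc3occn23)cc1` differs from compound 2 by 4-chlorophenyl in place of 2,3,4,5,6-pentafluorophenyl on a saturated chain carbon bound to an oxygen on an unsaturated carbon. Among the compounds with values here, the one measured step on this saturated chain carbon, a 1.1-fold higher number from compound 1 to compound 2 (0.05 log units; within the scatter), bears directly on the change and stayed within the scatter. No step beyond the scatter is therefore expected in this assay. The expected step from compound 2 to compound 3 is a 1.1-fold lower number from compound 2 to compound 3 (0.03 log units; within the scatter). Compound 3 is estimated at 1600 nM, within 700 nM to 3600 nM.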

Compound 3, half-maximal effective concentration: 990 nM
The estimate for compound 3 lay 1.6-fold (0.21 log units) above the measured number; the measured number falls inside the stated range.
By their numbers in this assay, from the lowest: compounds 3, 1 and 2 (each within the scatter of the next).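

Going from five fluorines to a single chlorine on the phenyl ring gives a 1.7-fold lower number from compound 2 to compound 3 (0.23 log units; within the scatter), so this saturated chain carbon has now carried three differently halogenated phenyl groups in this assay without any step beyond the scatter. Going by these compounds alone, the first change at a single ring position, hydrogen in place of chloro on an aromatic carbon, gives a 1.5-fold lower number from compound 1 to compound 3 (0.18 log units; within the scatter), so that chloro makes no readable difference here. No measurement on hand offers an explanation for these small steps. On these data alone, whether unsubstituted phenyl, an amine, a carboxylic acid or a longer chain at this place would move the number beyond the scatter stays open.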